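A few compounds are considered here, and "the series" means these few. Any claim that something is new, unique, unknown or untested is made for them only; others in the source may bear on it.

Of the compounds shown here, three sharing one core have been measured in an ADME assay on microsomes from liver (Homo sapiens) for metabolic stability, read by LC-MS, using NADPH, tested at 5 uM; on this read-out higher numbers stand for a longer-lived compound and lower numbers for a shorter-lived compound. Compound 1 `Cc1cc(-c2ccccc2)n(/C(N)=N/S(=O)(=O)c2cc(C)c(Cl)cc2SCc2ccccc2C(F)(F)F)n1` gives 0.306 h, compound 2 `Cc1cccc(CSc2cc(Cl)c(C)cc2S(=O)(=O)/N=C(\N)n2nccc2-c2ccccc2)c1` gives 0.232 h, and compound 3 `Cc1cc(-c2ccccc2)n(/C(N)=N/S(=O)(=O)c2cc(C)c(Cl)cc2SCc2ccccc2Cl)n1` gives 0.163 h. Compound 2 thus stands second of the three numbers, though its gaps to both neighbours are within the scatter, so no order among them can be claimed. Going by the values given here, the only measured step that changes one place is a 1.9-fold lower number from compound 1 to compound 3 (0.27 log units; within the scatter), and it too lies within the scatter; it concerns the group on the benzyl ring, the same region touched in the step considered here, but it swaps one substituent for another rather than removing one. Compound 4 `Cc1cc(S(=O)(=O)/N=C(\N)n2nccc2-c2ccccc2)c(SCc2ccccc2)cc1Cl` differs from compound 2 in that (hydrogen in place of methyl on an aromatic carbon). Among the compounds with values here, no measured pair shows this change, so the expectation rests on the small spread seen across compounds 1, 2 and 3 in this assay. Compound 4 is therefore expected to give 0.22 h, with a range from 0.11 h to 0.45 h, and the step of a 1.1-fold lower number from compound 2 to compound 4 (0.02 log units; within the scatter) is expected to stay within the scatter.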

Compound 4, half-life: 0.0772 h
Compound 4: middle estimate off by 2.8-fold (0.45 log units), on the high side; measured number below the stated range.
By their numbers in this assay, from the lowest: compound 4; then compounds 3, 2 and 1 (each within the scatter of the next).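

Changing 3-methylbenzyl to benzyl gives a 3.0-fold lower number from compound 2 to compound 4 (0.48 log units; beyond the scatter) in this assay and so shows that this one aromatic carbon can matter on this read-out. The earlier step on this ring, a 1.9-fold lower number from compound 1 to compound 3 (0.27 log units; within the scatter) stayed within the scatter, so it exchanged one substituent for another without showing any such sensitivity, whereas here the loss of a single carbon atom carries the number beyond the scatter. Nothing available accounts for this step.

The compounds shown do not tell whether methyl itself is needed at this place, or whether a methoxy, an ethyl or a fluoro group would hold the half-life as well. They also leave open whether the same change would give a step of similar size on a compound with other groups elsewhere on the shared core.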